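Triazole nitrogen substituent variation on a shared bicyclic core

A few compounds are considered here, and "the series" means these few. Any claim that something is new, unique, unknown or untested is made for them only; others in the source may bear on it.

Compound 3 `O=C1C[C@H](OCc2cn(-c3cccc(Cl)c3Cl)nn2)[C@H]2CO[C@@H]1O2` sits at 26000 nM in a functional assay on MDA-MB-231 cells (Homo sapiens) for cytotoxicity, read by MTT assay, with a stated time of 48 h; on this read-out higher numbers stand for weaker inhibition and lower numbers for stronger inhibition; among the three measured compounds it holds the second highest number. Compound 1 `O=C1C[C@H](OCc2cn(-c3ccccc3)nn2)[C@H]2CO[C@@H]1O2` gives 25200 nM in this assay, and compound 2 `CCCCn1cc(CO[C@H]2CC(=O)[C@@H]3OC[C@H]2O3)nn1` gives 27900 nM in this assay. The three steps that connect them all exchange the group on the aromatic nitrogen: a 1.1-fold higher number from compound 1 to compound 2 (0.04 log units; within the scatter), a 1.0-fold higher number from compound 1 to compound 3 (0.01 log units; within the scatter) and a 1.1-fold lower number from compound 2 to compound 3 (0.03 log units; within the scatter). None of the three moves the number beyond the scatter.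

Compound 4 `O=C1CCCCC1n1cc(CO[C@H]2CC(=O)[C@@H]3OC[C@H]2O3)nn1` is not yet measured. It differs from compound 3 at the same position: 2-oxocyclohexyl in place of 2,3-dichlorophenyl on an aromatic nitrogen. All three measured steps bear on this change, because each of them, a 1.1-fold higher number from compound 1 to compound 2 (0.04 log units; within the scatter), a 1.0-fold higher number from compound 1 to compound 3 (0.01 log units; within the scatter) and a 1.1-fold lower number from compound 2 to compound 3 (0.03 log units; within the scatter), also replaced the group on that aromatic nitrogen, and each stayed within the scatter. Whether a non-aromatic ring carrying a carbonyl behaves like the aromatic and chain groups tried so far is not settled by these three compounds, so the range is kept wide.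

On that basis no step beyond the scatter is expected, which amounts to an estimated no change at the digits printed from compound 3 to compound 4 (within the scatter). Compound 4 is therefore estimated at 26000 nM in this assay, with a range from 12000 nM to 55000 nM.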

Compound 4, half-maximal inhibitory concentration: 36000 nM
Estimate against measurement, compound 4: 1.4-fold (0.14 log units) below; the range from low to high includes it.
By their numbers in this assay, from the lowest: compounds 1, 3, 2 and 4 (each within the scatter of the next).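

With compound 4, a non-aromatic ring carrying a carbonyl, and with it a hydrogen-bond acceptor, joins the groups tried on the aromatic nitrogen, and in this assay it stays within the scatter of each of them: against 2,3-dichlorophenyl (a 1.4-fold higher number from compound 3 to compound 4 (0.14 log units; within the scatter)), against butyl (a 1.3-fold higher number from compound 2 to compound 4 (0.11 log units; within the scatter)) and against phenyl (a 1.4-fold higher number from compound 1 to compound 4 (0.15 log units; within the scatter)). Across the four compounds, then, neither an aromatic ring, a chain nor 2-oxocyclohexyl at this position separates from another beyond the scatter, which extends the flat picture from the aromatic and chain groups to a non-aromatic ring. Nothing in the available data offers an explanation for this flat picture.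

Still open, going by these compounds, is whether a group of another kind on this nitrogen, such as an amine, a carboxylic acid or a longer chain, would move the number beyond the scatter. All the steps shown lie at this one position, so what changes elsewhere on the shared core would do to the number also remains open.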